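Swapping the Amide Aryl Group: Methoxy Out, Methyl In

The compounds below may be only part of what the source reports. "The series", "measured", "known", "first", "only" and "open" are said of these compounds alone.

Compound 1 `COc1ccc2c(=O)c(/C=C/C(=O)NCc3cccc(F)c3)coc2c1` gives 17600 nM in a functional assay on HeLa cells (Homo sapiens) for inhibition, read by MTT assay, with a stated time of 48 h; on this read-out lower numbers stand for stronger inhibition and higher numbers for weaker inhibition. Compound 2 `COc1ccc(CNC(=O)/C=C/c2coc3cc(OC)ccc3c2=O)cc1` gives > 100000 nM in this assay, which is a limit, not a number. Compound 3 `COc1ccc2c(=O)c(/C=C/C(=O)Nc3ccccc3OC)coc2c1` gives > 100000 nM in this assay, again a limit rather than a number.

Compound 3 therefore stands at the weak end of what the numbers can show, sitting at the limit of > 100000 nM in this assay, at which 2 of the 3 values shown sit. The two readable steps both run away from compound 1: an at least 5.6-fold higher number from compound 1 to compound 2 (0.75 log units; beyond the scatter) and an at least 5.6-fold higher number from compound 1 to compound 3 (0.75 log units; beyond the scatter). The step that the two limits leave unreadable from compound 2 to compound 3 cannot be sized.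

Compound 4 `COc1ccc2c(=O)c(/C=C/C(=O)Nc3ccc(C)cc3)coc2c1` differs from compound 3 by 4-methylphenyl in place of 2-methoxyphenyl on an amide-type nitrogen. Going by the values given here, no measured step swaps one substituent for another on the same amide-bound phenyl ring, so none bears directly on this change. Since compound 3 gives only a limit, a step to compound 4 would be readable in one direction alone. The expectation is that compound 4 remains near the limit, and it is estimated at 90000 nM, ranging from 20000 nM to 300000 nM, which means an expected step of an at least 1.1-fold lower number from compound 3 to compound 4 (0.04 log units; that floor lies within the scatter).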

Compound 4, half-maximal inhibitory concentration: 24100 nM
The estimate for compound 4 lay 3.7-fold (0.57 log units) above the measured number, and the stated range covers the measured number.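

Putting 4-methylphenyl in place of 2-methoxyphenyl on the amide-type nitrogen gives an at least 4.1-fold lower number from compound 3 to compound 4 (0.61 log units; beyond the scatter), so a phenyl ring bound directly to that nitrogen can give a readable number in this assay. Going by these compounds alone, the same holds against the other compound held at the limit, with an at least 4.1-fold lower number from compound 2 to compound 4 (0.61 log units; beyond the scatter), while the comparison with the only other readable compound gives a 1.4-fold higher number from compound 1 to compound 4 (0.14 log units; within the scatter), so the benzyl-type chain of compound 1 is not needed for a value in this range. Among these four compounds, the two with readable numbers carry no methoxy group on the amide-side ring, and the two that carry one stay at a limit, which is not a number: the limit of > 100000 nM in this assay, at which 2 of the 4 values shown sit.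

Compound 3 and compound 4 differ both in the group on the ring and in the name's ring position, so these compounds cannot separate the two, and a 4-methoxyphenyl or 2-methylphenyl group on the amide-type nitrogen would be the direct test. On these data alone, how a ring bearing an amine or a carboxylic acid would read in this assay also stays open.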